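The compounds below may be only part of what the source reports. "The series", "measured", "known", "first", "only" and "open" are said of these compounds alone.

Of the compounds shown here, three built on the shared core have been tested in a functional assay on DU-145 cells (Homo sapiens) for cytotoxicity, read by MTT assay, with a stated time of 48 h; a lower number here means a stronger inhibitor, a higher number a weaker inhibitor. For compound 1 `CCCCCCCCCNC(=O)N(Cc1cc(OC)ccc1OC)n1cnnc1` the result is a limit of the assay, > 50000 nM. Compound 2 `COc1cc(CN(C(=O)Nc2ccc(C)cc2)n2cnnc2)cc(OC)c1OC` gives a number, 20800 nM. For compound 3 `COc1ccc(CN(C(=O)Nc2ccc(Cl)c(C(F)(F)F)c2)n2cnnc2)cc1OC` the result is again a limit of the assay, > 50000 nM, so compound 3 stands among the measured compounds only as a limit and not as a number, its position marked by the limit of > 50000 nM in this assay, at which 2 of the 3 values shown sit. Going by the values given here, no two of the measured compounds differ in a single place, so no measured step exists to show how one exchange shifts the read-out. Compound 4 `Cc1ccsc1CN(C(=O)Nc1ccc(Cl)c(C(F)(F)F)c1)n1cnnc1` differs from compound 3 in one place: 3-methylthiophen-2-yl in place of 3,4-dimethoxyphenyl on a saturated chain carbon bound to an amide-type nitrogen. With nothing measured for an exchange of this kind, the step expected from this change, an at least 1.1-fold lower number from compound 3 to compound 4 (0.04 log units; that floor lies within the scatter), is no larger than the scatter, and in view of the limit of > 50000 nM in this assay, at which 2 of the 3 values shown sit, the expected outcome for compound 4 may once more be a limit. Compound 4 is therefore estimated at 45000 nM, within a range from 12000 nM to 150000 nM.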

Compound 4, half-maximal inhibitory concentration: 24100 nM
The estimate for compound 4 lay 1.9-fold (0.27 log units) above the measured number; the measured number falls inside the stated range.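

In this assay, going by these compounds alone, 3-methylthiophen-2-yl in place of 3,4-dimethoxyphenyl on a saturated chain carbon bound to an amide-type nitrogen gives the only measured step at this position: an at least 2.0-fold lower number from compound 3 to compound 4 (0.31 log units; beyond the scatter). On these data alone, compound 3 gives > 50000 nM, a limit of the assay and not a number, so only a floor is known for the step and its full size stays open: the limit of > 50000 nM in this assay, at which 2 of the 4 values shown sit. Within the data shown here, the read-out therefore does respond to the group on this carbon, which the earlier compounds, none of which differ in a single place, could not show.

This one exchange alters the ring size, the sulfur and the methyl group together, and the compounds shown do not separate these. Also open, as far as these compounds go, is how an unsubstituted thiophen-2-yl or a plain phenyl would read at this position.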